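A few compounds are considered here, and "the series" means these few. Any claim that something is new, unique, unknown or untested is made for them only; others in the source may bear on it.

Working notes on the series. Three compounds share one core and differ only in the group on the amide-type nitrogen. In a functional assay on MCF7 cells (Homo sapiens) for inhibition, read by MTT assay, with a stated time of 72 h (a lower number here means a stronger inhibitor, a higher number a weaker inhibitor), compound 1 `Cc1ccc(NC(=O)c2ccc(/N=N\c3c[nH]c4ccccc34)cc2)cc1` gives 42400 nM, compound 2 `O=C(Nc1ccccc1[N+](=O)[O-])c1ccc(/N=N\c2c[nH]c3ccccc23)cc1` gives 101000 nM, and compound 3 `O=C(Nc1cccc(Cl)c1)c1ccc(/N=N\c2c[nH]c3ccccc23)cc1` gives 82700 nM. Compound 2 holds the highest number of the three: the step of a 2.4-fold higher number from compound 1 to compound 2 (0.38 log units; beyond the scatter) lies beyond the scatter, whereas the step of a 1.2-fold lower number from compound 2 to compound 3 (0.09 log units; within the scatter) and the step of a 2.0-fold higher number from compound 1 to compound 3 (0.29 log units; within the scatter) do not separate their pairs.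

Compound 4 `O=C(Nc1cccc([N+](=O)[O-])c1)c1ccc(/N=N\c2c[nH]c3ccccc23)cc1` is not yet measured. Its change from compound 2 is 3-nitrophenyl in place of 2-nitrophenyl on an amide-type nitrogen. Among the compounds with values here, the nearest precedent is the step of a 1.2-fold lower number from compound 2 to compound 3 (0.09 log units; within the scatter), in which a different group was set on the same amide-type nitrogen in place of 2-nitrophenyl and the number hardly moved; the step of a 2.0-fold higher number from compound 1 to compound 3 (0.29 log units; within the scatter) likewise stayed within the scatter. Within the data shown here, no measured pair exchanges 2-nitrophenyl for 3-nitrophenyl directly, so the evidence is indirect.

On that basis no step beyond the scatter is expected in this assay for compound 4, with the balance, if any, toward a somewhat lower number, as the step of a 1.3-fold lower number from compound 2 to compound 4 (0.10 log units; within the scatter) expresses. Compound 4 is therefore estimated at 80000 nM, within a range from 35000 nM to 180000 nM.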

Compound 4, half-maximal inhibitory concentration: 51900 nM
The estimate for compound 4 lay 1.5-fold (0.19 log units) above the measured number; the range from low to high includes it.
By their numbers in this assay, from the lowest: compounds 1, 4, 3 and 2 (each within the scatter of the next, the first and the last beyond it).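

Compounds 2 and 4 hold the same atoms joined differently, so this pair isolates the exchange of 2-nitrophenyl for 3-nitrophenyl on the amide-type nitrogen; in this assay the result is a 1.9-fold lower number from compound 2 to compound 4 (0.29 log units; within the scatter), so this exchange does not separate the pair. The same holds for the first exchange made on the aromatic carbon alone, with a 1.6-fold lower number from compound 3 to compound 4 (0.20 log units; within the scatter), and nitro in place of chloro therefore gives no readable change at this level of scatter. Within the data shown here, compound 4 also stays with the 4-methylphenyl compound, with a 1.2-fold higher number from compound 1 to compound 4 (0.09 log units; within the scatter), so among the four compounds a 2.4-fold higher number from compound 1 to compound 2 (0.38 log units; beyond the scatter) remains the only step beyond the scatter, and all four groups so far give numbers close together, with 2-nitrophenyl the sole group separated from 4-methylphenyl.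

No measurement bears on why the 2-nitrophenyl and 3-nitrophenyl compounds fall where they do, and no cause can be assigned to either step. Still open, from the compounds shown here alone, is whether an aminophenyl group, a carboxyphenyl group or a longer alkyl chain on the same amide-type nitrogen would move the number beyond the scatter from compound 4.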